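Cyclohexyl Amide Expected to Stay Near the Tolerance Ceiling

The source may hold more compounds than are shown below. What is called first, only, known or untested is meant among the compounds shown, and "the series" means these compounds.

Compound 2 `CCCC(=O)N(C)c1ccc(C(O)(C(F)(F)F)C(F)(F)F)cc1` sits at a limit of an ADME assay on Li23 cells (Homo sapiens) for cytotoxicity, read by WST assay; a lower number here means that less compound is tolerated, a higher number that more compound is tolerated: its reading of > 100000 nM marks the top of what the assay reports, not a measured number. Its neighbour compound 1 `Cc1cccc(C(=O)N(C)c2ccc(C(O)(C(F)(F)F)C(F)(F)F)cc2)c1` gives a numerical value of 20000 nM in this assay. Among the measured compounds shown here, the single measured step, an at least 5.0-fold higher number from compound 1 to compound 2 (0.69 log units; beyond the scatter), shows that replacing the aromatic ring on the carbonyl carbon with a short chain raised tolerance, though the limit of > 100000 nM in this assay, at which 1 of the 2 values shown sits, means only the lower edge of that step is known.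

Compound 3 `CN(C(=O)C1CCCCC1)c1ccc(C(O)(C(F)(F)F)C(F)(F)F)cc1` differs from compound 2 in one place: cyclohexyl in place of propyl on a carbonyl carbon. For the measured compounds named here, no measured pair tells how a saturated ring behaves at this position; the one step available runs from an aromatic ring to a chain. The cyclohexyl group lies structurally between the two measured groups, so the expectation for compound 3 is a value at or somewhat under the ceiling, a step of an at least 1.2-fold lower number from compound 2 to compound 3 (0.09 log units; that floor lies within the scatter) from compound 2 to compound 3. Compound 3 is estimated at 80000 nM, with a range from 30000 nM to 200000 nM, and a fair chance that only a limit is reported.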

Compound 3, half-maximal cytotoxic concentration: 20000 nM
The estimate for compound 3 lay 4.0-fold (0.60 log units) above the measured number, and the stated range ends above it.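

In this assay, the saturated ring does not keep the tolerance of the short chain: cyclohexyl in place of propyl on a carbonyl carbon gives an at least 5.0-fold lower number from compound 2 to compound 3 (0.69 log units; beyond the scatter). The change from an aromatic to a saturated ring gives no change at the digits printed from compound 1 to compound 3 (within the scatter), so within these three compounds, whether the ring on the carbonyl carbon is aromatic has no readable effect, and the two ring-bearing compounds read alike while only the propyl compound stands apart. How far the propyl compound stands from the other two remains unknown, with only the lower edge of each step to it in hand: the limit of > 100000 nM in this assay, at which 1 of the 3 values shown sits.

What the compounds shown leave open is whether the ring itself or simply the larger number of carbon atoms brings the number down, a question that a pentyl or hexyl chain set against a cyclopropyl ring at this position could separate. Also open, on these data alone, is whether a ring or chain carrying a nitrogen, such as a piperidine, or a carboxylic acid at the end of the chain, would read like the propyl compound or like the two ring-bearing compounds.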